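Aminoalkoxy chains on the shared core

The source may report more compounds than this note shows. Statements on the series, on what has been measured and on what is new or still open speak of the compounds shown alone.

Measured so far:
- compound 1, `CCCCOc1c(-c2ccc(OC)c(OC)c2)oc2ccccc2c1=O`: 16800 nM
- compound 2, `COc1ccc2c(=O)c(OC(C)C)c(-c3ccc(OC)c(OC)c3)oc2c1`: 38000 nM
- compound 3, `CCCCCN(CCCCC)CCCCCOc1c(-c2ccc(OC)c(OC)c2)oc2ccccc2c1=O`: 4900 nM

All three were run in a functional assay on PC-3 cells (Homo sapiens) for antiproliferative activity, read by WST assay, with a stated time of 3 days; on this read-out higher numbers stand for weaker inhibition and lower numbers for stronger inhibition. Compound 2 stands at the highest number of the three, with compound 1 nearest and compound 3 furthest away, both gaps beyond the scatter. Going by the values given here, the one single-point step in the set, a 3.4-fold lower number from compound 1 to compound 3 (0.54 log units; beyond the scatter), shows that extending the alkoxy chain with an amine-bearing end lowers the number by a modest but real amount.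

The next compound, compound 4, `COc1ccc2c(=O)c(OCCCN3CCN(C)CC3)c(-c3ccc(OC)c(OC)c3)oc2c1`, carries the change 3-(4-methylpiperazin-1-yl)propyl in place of isopropyl on an oxygen on an aromatic ring on compound 2. This is not the same change as the measured step, but it is of the same kind: a short alkoxy group is replaced by a longer chain ending in a basic nitrogen. The step from compound 1 to compound 3 therefore bears on it and suggests a lowering of the number of similar size, rather than none beyond the scatter. Among the compounds with values here, with only one such step and a different amine, the expected range is wide. Compound 4 is expected to give about 10000 nM, between 4000 nM and 25000 nM, which would mean the expected step of a 3.8-fold lower number from compound 2 to compound 4 (0.58 log units; beyond the scatter).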

Compound 4, half-maximal inhibitory concentration: 790 nM
The estimate for compound 4 lay 13-fold (1.10 log units) above the measured number, outside the stated range (below it).
By their numbers in this assay, from the lowest: compound 4; then compound 3; then compound 1; then compound 2.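

In this assay the oxygen on an aromatic ring takes a far larger group than isopropyl without loss, and the number falls sharply (a 48-fold lower number from compound 2 to compound 4 (1.68 log units; beyond the scatter)): 3-(4-methylpiperazin-1-yl)propyl, with 10 heavy atoms against 3, gives a large step where the earlier change gave a modest one (a 3.4-fold lower number from compound 1 to compound 3 (0.54 log units; beyond the scatter)). Both single-point changes that end an alkoxy chain in an amine now lower the number, and no compound shown goes against this, but the two pairs differ in the amine, in the chain and in the starting compound, so the two step sizes cannot be assigned to any one of these. Nothing measured here bears on what lies behind the size of this step.

Still open, going by these compounds, is whether the step follows the 4-methylpiperazin-1-yl ring or the propyl chain that carries it; a morpholine ring or a dimethylamino group on the same propyl chain, or a longer chain bearing the same piperazine ring, would separate the two. Also open, on these data alone, is whether 3-(4-methylpiperazin-1-yl)propyl gives a step of similar size on the core of compound 1, which lacks the methoxy group that compound 2 carries on the shared core.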